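A new aryl group on an inactive series

A few compounds are considered here, and "the series" means these few. Any claim that something is new, unique, unknown or untested is made for them only; others in the source may bear on it.

Compound 1 `Nc1ncnn2c([C@@H]3O[C@H](CO)[C@@H](O)[C@H]3O)cc(-c3ccccc3)c12`: > 100000 nM
Compound 2 `Nc1ncnn2c([C@@H]3O[C@H](CO)[C@@H](O)[C@H]3O)cc(-c3ccc(F)cc3)c12`: > 100000 nM

Both entries come from a functional assay on K562 cells (Homo sapiens) for antiproliferative activity, with a stated time of 72 h (a higher number here means a weaker inhibitor, a lower number a stronger inhibitor), and each is a limit of the assay, not a number. Compound 2 stands at > 100000 nM, which is a limit. Among the measured compounds shown here, the summary for the series so far is the limit of > 100000 nM in this assay, at which 2 of the 2 values shown sit.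

The next compound is compound 3 `Cc1ccccc1-c1cc([C@@H]2O[C@H](CO)[C@@H](O)[C@H]2O)n2ncnc(N)c12`, which keeps the shared core and changes one group: 2-methylphenyl in place of 4-fluorophenyl on an aromatic carbon. Here 2-methylphenyl sits in place of 4-fluorophenyl on an aromatic carbon.

For the measured compounds named here, only one measured step bears on this change. It is a step that the two limits leave unreadable from compound 1 to compound 2, with fluoro in place of hydrogen on an aromatic carbon. That step has no readable size, so the data offer neither a size nor a direction to carry over. The expectation therefore rests on compound 2 and on the limit of > 100000 nM in this assay, at which 2 of the 2 values shown sit: no step beyond the scatter is expected in this assay, and the assay will most likely report only a limit again. The expected step is a number no higher from compound 2 to compound 3 (the limit leaves the size open). For compound 3 the estimated value is 100000 nM, with an expected range from 40000 nM to 250000 nM.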

Compound 3, half-maximal inhibitory concentration: > 100000 nM
Compound 3 ended at the assay's limit; the forecaster's own chance of this, stated with the estimate: 80%; the middle value lies on the limit itself.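

In this assay compound 3 gives > 100000 nM, which is a limit of the assay and not a number. Among the compounds shown here, no step among compound 1, compound 2 and compound 3 can be read. The compounds shown leave open whether any aryl group at this place on the shared core would give a measurable value in this assay.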